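Bis-sulfonyl piperidine carboxamides: amide substituent exchange

The source may report more compounds than this note shows. Statements on the series, on what has been measured and on what is new or still open speak of the compounds shown alone.

Measured so far:
compound 1 `CCN(CC)S(=O)(=O)c1ccc(S(=O)(=O)N2CCC[C@@H](C(=O)N[C@@H]3CCN(C(=O)OC(C)(C)C)C3)C2)cc1` — 200 nM
compound 2 `CCOC(=O)[C@@H]1CCCN(S(=O)(=O)c2ccc(S(=O)(=O)N3CCOCC3)cc2)C1` — 23500 nM
compound 3 `CCN(CC)S(=O)(=O)c1ccc(S(=O)(=O)N2CCC[C@@H](C(=O)N3CCN(c4nc(C(F)(F)F)no4)CC3)C2)cc1` — 600 nM

In a functional assay on MIA PaCa-2 cells (Homo sapiens) for inhibition, read by MTT assay, with a stated time of 7 days (on this read-out higher numbers stand for weaker inhibition and lower numbers for stronger inhibition), compound 1 holds the lowest number of the three measured compounds. The nearest neighbour is compound 3 with 600 nM, a higher number that lies beyond the scatter of the method, so compound 1 is the stronger inhibitor of that pair. Compound 2 gives 23500 nM, by far the highest number of the set and well beyond the scatter from compound 1; compound 2 also lacks the amide that compounds 1 and 3 share, so its value says little about the amide substituent itself.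

Compound 4 `CCN1CC(NC(=O)[C@@H]2CCCN(S(=O)(=O)c3ccc(S(=O)(=O)N(CC)CC)cc3)C2)C1` keeps the whole core of compound 1 and changes only the amide substituent: 1-ethylazetidin-3-yl in place of 1-(tert-butoxycarbonyl)pyrrolidin-3-yl on an amide-type nitrogen. Within the data shown here, no measured pair shows this exchange, so the expected size of the step rests on the position alone, where compounds 1 and 3 already differ beyond the scatter. A moderate shift toward weaker inhibition in this assay is expected, though a result within the scatter cannot be excluded. The expected step of a 2.5-fold higher number from compound 1 to compound 4 (0.40 log units; beyond the scatter) is therefore upward and modest. For compound 4 the estimate in this assay is 500 nM, with an expected range from 120 nM to 2500 nM.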

Compound 4, half-maximal inhibitory concentration: > 30000 nM
Compound 4 was reported as a limit (the forecaster's own chance of this, stated with the estimate: 5%); at least 60-fold (1.77 log units) between middle value and limit.
By their numbers in this assay, from the lowest: compound 1; then compound 3; then compound 2. At a limit, above all of these: compound 4.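

With the shared core held fixed, 1-ethylazetidin-3-yl in place of 1-(tert-butoxycarbonyl)pyrrolidin-3-yl on an amide-type nitrogen gives, in this assay, an at least 150-fold higher number from compound 1 to compound 4 (2.17 log units; beyond the scatter). Among these compounds, this is the first single-place comparison, and it shows that the amide substituent alone can decide between a sub-micromolar reading and no measurable inhibition within the range of this assay, so this position is not a freely exchangeable one. Compound 4 is reported as a limit and not a number, so the step has a lower bound only: the limit of > 30000 nM in this assay, at which 1 of the 4 values shown sits.

The exchange alters the ring size and replaces the tert-butoxycarbonyl group with ethyl in a single move, and the compounds shown cannot assign the loss to either part, nor to the carbonyl and oxygen atoms that leave with the carbamate. A 1-ethylpyrrolidin-3-yl group and a 1-(tert-butoxycarbonyl)azetidin-3-yl group would each separate these two parts, while the unsubstituted pyrrolidin-3-yl amine would show whether any group on that ring nitrogen is needed.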